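Reading a methoxy compound against its ethyl neighbour

A few compounds are considered here, and "the series" means these few. Any claim that something is new, unique, unknown or untested is made for them only; others in the source may bear on it.

Measured so far in a functional assay on SMOV2 cells (Homo sapiens) for antiproliferative activity, read by sulforhodamine B assay, with a stated time of 3 days; a lower number here means a stronger inhibitor of growth, a higher number a weaker inhibitor of growth:
- Compound 1 `Cc1cc(-c2nc(-c3ccc4[nH]c(=O)oc4c3)cs2)ccc1F` gives 250 nM
- Compound 2 `CCc1cc(F)ccc1-c1nc(-c2ccc3[nH]c(=O)oc3c2)cs1` gives 13 nM
- Compound 3 `COc1cc(F)ccc1-c1nc(-c2ccc3[nH]c(=O)oc3c2)cs1` gives 5700 nM

Of the three, compound 3 has the highest number (5700 nM). Compound 1 gives 250 nM, well short of that number, and compound 2 gives 13 nM, the lowest of the three.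

Compound 4 `CN(C)Cc1cc(F)ccc1-c1nc(-c2ccc3[nH]c(=O)oc3c2)cs1` has not yet been measured. It carries (dimethylamino)methyl in place of methoxy on an aromatic carbon, ortho to a large group and meta to a fluoro group: (dimethylamino)methyl in place of methoxy on an aromatic carbon.

For the measured compounds named here, one measured step bears directly on this place. It is large: a 440-fold higher number from compound 2 to compound 3 (2.64 log units; beyond the scatter), with methoxy in place of ethyl on an aromatic carbon. The entering group resembles the ethyl of compound 2 in joining the ring through a carbon, which suggests that some of that step may be recovered. Going by the values given here, no measured compound has an amine at this place, however, and only a partial recovery is expected, with wide uncertainty.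

The expected change in this assay is toward a lower number: an 11-fold lower number from compound 3 to compound 4 (1.06 log units; beyond the scatter). For compound 4 the estimated value is 500 nM, with an expected range from 50 nM to 5000 nM.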

Compound 4, concentration for 50% growth inhibition: 10 nM
The estimate for compound 4 lay 50-fold (1.70 log units) above the measured number; the measured number lies below the stated range.
By their numbers in this assay, from the lowest: compounds 4 and 2 (each within the scatter of the next); then compound 1; then compound 3.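

In this assay, the (dimethylamino)methyl group of compound 4, on an aromatic carbon ortho to a large group and meta to a fluoro group, reverses the loss that came with methoxy at this place: a 570-fold lower number from compound 3 to compound 4 (2.76 log units; beyond the scatter), against a 440-fold higher number from compound 2 to compound 3 (2.64 log units; beyond the scatter) in the opposite direction. The comparison with ethyl gives a 1.3-fold lower number from compound 2 to compound 4 (0.11 log units; within the scatter), so compound 4 and compound 2 cannot be told apart here, although the entering group has more heavy atoms and contains a nitrogen, which shows that this place can hold a nitrogen-bearing chain as well as ethyl. No measurement here accounts for the gap between methoxy and the two groups that join the ring through a carbon.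

The compounds shown leave open whether the oxygen of methoxy, joined directly to the ring, is what sets compound 3 apart, a question that a methoxymethyl group at this place would address. They also leave open whether the nitrogen of compound 4 matters at all, and how a propyl chain, a primary amine or a pyrrolidinylmethyl group would read at the same place.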